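Amide series notes: 6-methylpyridin-2-yl in place of 4-methoxyphenyl

A few compounds are considered here, and "the series" means these few. Any claim that something is new, unique, unknown or untested is made for them only; others in the source may bear on it.

Measured so far:
compound 1, `COc1ccc(C(=O)N[C@H]2CCC[C@H](NC(=O)c3cccc(Cl)c3)C2)cc1`, 266 nM
compound 2, `O=C(N[C@H]1CCC[C@H](NC(=O)c2cccc(F)c2)C1)c1cccc(F)c1`, 593 nM

Both compounds were run in a functional assay on HEK293 cells for antagonist activity at metabotropic glutamate receptor 5 (Homo sapiens), read by FLIPR and calcium flux; on this read-out higher numbers stand for weaker inhibition and lower numbers for stronger inhibition. In this assay compound 1 gives 266 nM, and compound 2 gives 593 nM. Compound 1 therefore holds the lowest of the two numbers; the gap to compound 2 lies beyond the usual scatter, so compound 1 is the stronger inhibitor of the pair as things stand.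

The next compound in line is compound 3, `Cc1cccc(C(=O)N[C@H]2CCC[C@H](NC(=O)c3cccc(Cl)c3)C2)n1`, which has not yet been measured in this assay. Relative to compound 1 the change is one of the two amide groups of the shared core:

6-methylpyridin-2-yl in place of 4-methoxyphenyl on a carbonyl carbon

Within the data shown here, no measured pair of compounds shows this same change, so no step of known size is available to guide the expectation. On the two numbers at hand the change is expected to move the read-out only modestly, if at all: the step of a 1.4-fold higher number from compound 1 to compound 3 (0.15 log units; within the scatter) in this assay is estimated to be small and toward a slightly higher number, at the edge of the usual scatter. Compound 3 is accordingly expected to give 380 nM in this assay, with a plausible range from 110 nM to 1300 nM.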

Compound 3, half-maximal inhibitory concentration: 290 nM
Beside the measured number, compound 3's estimate is 1.3-fold (0.12 log units) above it; low and high end bracket the measured number.
By their numbers in this assay, from the lowest: compounds 1 and 3 (each within the scatter of the next); then compound 2.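

In this assay, 6-methylpyridin-2-yl in place of 4-methoxyphenyl on a carbonyl carbon gives a 1.1-fold higher number from compound 1 to compound 3 (0.04 log units; within the scatter), so the two groups cannot be told apart at this position on this read-out. Among these compounds, the other amide group stays as it is in compound 1, which makes this the first step that reads a single position; compound 1 and compound 2 differ in more than one place and could not show this. No measurement is available that would explain why the exchange of a carbon-only aromatic ring for one with a hetero atom leaves the read-out within the scatter.

Since 6-methylpyridin-2-yl differs from 4-methoxyphenyl in both its ring and its substituent, the compounds shown do not separate what each contributes, and pyridin-2-yl without the methyl group would be needed to do so. From the compounds shown here alone, it also remains open whether the equivalence holds with a different group on the other amide, and how this position responds to a non-aromatic group such as a piperidine, a carboxylic acid or a longer alkyl chain.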